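A few compounds are considered here, and "the series" means these few. Any claim that something is new, unique, unknown or untested is made for them only; others in the source may bear on it.

Measured so far in an ADME assay on RD cells (Homo sapiens) for cytotoxicity, read by MTT assay, with a stated time of 3 days; a lower number here means that less compound is tolerated, a higher number that more compound is tolerated:
- compound 1 `CC[C@H](CCn1cncn1)c1ccccc1` gives 99.8 ug/mL
- compound 2 `CC[C@@H](CCn1cncn1)c1ccccc1` gives 91.2 ug/mL
- compound 3 `CC[C@H](CCn1cncn1)c1ccc(F)cc1` gives 110 ug/mL

Compound 1 stands second highest of these three numbers, with compound 2 nearest and compound 3 furthest, yet both gaps lie within the scatter of this kind of measurement. The step of a 1.1-fold lower number from compound 1 to compound 2 (0.04 log units; within the scatter) moves nothing beyond that scatter, which fits (the fact that compounds 1 and 2 differ only in the configuration as drawn). The step of a 1.1-fold higher number from compound 1 to compound 3 (0.04 log units; within the scatter) is equally small.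

Compound 4 `c1ccc(C[C@H](CCn2cncn2)c2ccccc2)cc1` is the next compound to be measured in this assay. It differs from compound 1 in one place: phenyl in place of methyl on a saturated chain carbon, two bonds along the chain from an aromatic carbon. Neither measured step tries out anything of this kind: one turns the drawn configuration at a saturated chain carbon, the other puts fluoro on an aromatic carbon, and both left the number essentially where it was. The replacement of methyl by phenyl is therefore untested here, and the three measured compounds give no direction for it. The expectation for compound 4 is a step of a 1.2-fold lower number from compound 1 to compound 4 (0.10 log units; within the scatter), a number somewhat on the low side of compound 1 but not clearly beyond the scatter. Compound 4 is estimated at 80 ug/mL, expected to fall between 40 ug/mL and 140 ug/mL.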

Compound 4, half-maximal cytotoxic concentration: 55.4 ug/mL
For compound 4 the middle estimate is 1.4-fold (0.16 log units) above the measured one; low and high end bracket the measured number.
By their numbers in this assay, from the lowest: compounds 4, 2, 1 and 3 (each within the scatter of the next).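

In this assay the change of ethyl to benzyl gives a 1.8-fold lower number from compound 1 to compound 4 (0.26 log units; within the scatter) and so stays within the scatter, even though a whole aromatic ring enters at the end of the chain. Going by these compounds alone, this is the first sign that this place, which none of the earlier steps touched, can carry a much larger group than methyl without a clear shift in the number, although a single step cannot rule out a small real drop hidden inside the scatter. The only explanatory fact available concerns configuration and does not bear on this replacement, so nothing here accounts for the size or direction of this step.

Going by these compounds, whether a longer chain of saturated carbons, an amine or a carboxylic acid in the same place would also keep the number close to that of compound 1 remains open. On these data alone, it is also open whether fluoro on an aromatic carbon or the opposite drawn configuration, both of which left the number essentially unmoved around compound 1, would do the same around compound 4.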